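Working notes: compound 3 to compound 4

The source may hold more compounds than are shown below. What is called first, only, known or untested is meant among the compounds shown, and "the series" means these compounds.

Values in an ADME assay on RAW264.7 cells (Mus musculus) for cytotoxicity, read by MTT assay, with a stated time of 24 h; on this read-out lower numbers stand for stronger inhibition and higher numbers for weaker inhibition:
- compound 1 `CS(=O)(=O)Oc1ccc2c3c(c(=O)oc2c1)CCCCCC3`: 24500 nM
- compound 2 `CCCS(=O)(=O)Oc1ccc2c3c(c(=O)oc2c1)CCCCCC3`: 9200 nM
- compound 3 `O=c1oc2cc(OS(=O)(=O)C3CC3)ccc2c2c1CCCCCC2`: 10500 nM

Compound 3 stands level with compound 2 on these numbers, with a 1.1-fold higher number from compound 2 to compound 3 (0.06 log units; within the scatter). Compound 1 has the highest number of the three, with a 2.3-fold lower number from compound 1 to compound 3 (0.37 log units; beyond the scatter).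

The next compound to be measured is compound 4 `Cc1ccc(S(=O)(=O)Oc2ccc3c4c(c(=O)oc3c2)CCCCCC4)cc1`, which has 4-methylphenyl in place of cyclopropyl on a sulfonyl sulfur.

Within the data shown here, the measured changes at this sulfonyl sulfur are the only guide. Leaving methyl gave modest steps, the other being a 2.7-fold lower number from compound 1 to compound 2 (0.43 log units; beyond the scatter), while propyl and cyclopropyl could not be told apart. No aromatic group on the sulfonyl sulfur has been measured, so these steps carry over only loosely. A slightly lower number in this assay seems likelier than a higher one, but no step beyond the scatter is expected, and the estimate is a 1.3-fold lower number from compound 3 to compound 4 (0.12 log units; within the scatter). The expected value for compound 4 is 8000 nM, with an estimated range from 3000 nM to 20000 nM.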

Compound 4, half-maximal inhibitory concentration: > 100000 nM
Compound 4: no number, only a limit (the forecaster's own chance of this, stated with the estimate: 10%); middle value at least 12-fold (1.09 log units) from the limit.
By their numbers in this assay, from the lowest: compounds 2 and 3 (each within the scatter of the next); then compound 1. At a limit, above all of these: compound 4.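

Compound 4 carries a limit of the assay, not a number, in this assay: the limit of > 100000 nM in this assay, at which 1 of the 4 values shown sits.

Among these compounds, with 4-methylphenyl on the sulfonyl sulfur, this position shows its largest steps so far: an at least 9.5-fold higher number from compound 3 to compound 4 (0.97 log units; beyond the scatter), an at least 10-fold higher number from compound 2 to compound 4 (1.03 log units; beyond the scatter) and an at least 4.0-fold higher number from compound 1 to compound 4 (0.61 log units; beyond the scatter). Compounds 2 and 3 both gave lower numbers than compound 1 with a larger group in place of methyl, and compound 4 goes against that pattern, so the size of the group on the sulfur does not by itself set the direction here.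

Open, on these data alone, is whether this shift belongs to the aromatic ring itself or to its methyl group, which a plain phenyl group would separate. Also open, as far as these compounds go, is whether a longer chain such as hexyl stays with propyl and cyclopropyl or moves towards compound 4.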